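Swapping a fluoro for a methoxy on the benzyl ring

The source may report more compounds than this note shows. Statements on the series, on what has been measured and on what is new or still open speak of the compounds shown alone.

Three compounds share one core and differ only in the substituted benzyl group attached to the ring nitrogen. In a functional assay on SW-620 cells (Homo sapiens) for inhibition, read by sulforhodamine B assay, with a stated time of 48 h (a lower number here means a stronger inhibitor of growth, a higher number a weaker inhibitor of growth), compound 3 `Nc1cc(N)c2nc(-c3ccccc3)c(NCc3ccc(F)cc3)nc2c1` gives 9550 nM, the lowest of the two numbers that have been reported. Compound 1 `Nc1cc(N)c2nc(-c3ccccc3)c(NCc3ccc(Cl)c(Cl)c3)nc2c1` gives 9770 nM in this assay, and the step of a 1.0-fold lower number from compound 1 to compound 3 (0.01 log units; within the scatter) is too small to count as a real difference. Compound 2 `COc1ccc(CNc2nc3cc(N)cc(N)c3nc2-c2ccccc2)cc1OC` is recorded in this assay only as a limit, < 100000 nM, so the steps a step that the limit leaves unreadable from compound 1 to compound 2 and a step that the limit leaves unreadable from compound 2 to compound 3 cannot be sized (the limit of < 100000 nM in this assay, at which 1 of the 3 values shown sits).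

Compound 4 `COc1ccc(CNc2nc3cc(N)cc(N)c3nc2-c2ccccc2)cc1` is the next member of the series. Among the compounds with values here, its only difference from compound 3 is methoxy in place of fluoro on an aromatic carbon. Within the data shown here, the one readable step, from a dichloro pair to a single fluoro, left the number essentially unchanged, which suggests this part of the molecule tolerates variation. Among the measured compounds shown here, compound 2, the only other methoxy-bearing member, was reported as a limit rather than a number, which leaves a real chance that compound 4 ends the same way. The expected step of a 1.4-fold higher number from compound 3 to compound 4 (0.13 log units; within the scatter) is therefore small, leaning toward a weaker inhibitor. Compound 4 is estimated to give about 13000 nM in this assay, within a range from 5000 nM to 45000 nM.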

Compound 4, concentration for total growth inhibition: 30200 nM
For compound 4 the middle estimate is 2.3-fold (0.37 log units) below the measured one, and the stated range covers the measured number.
By their numbers in this assay, from the lowest: compounds 3 and 1 (each within the scatter of the next); then compound 4.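

Within the data shown here, this is the first step at this position that lies beyond the scatter: in this assay, the change shows a 3.2-fold higher number from compound 3 to compound 4 (0.50 log units; beyond the scatter), so methoxy in place of fluoro on the benzyl ring does register, though modestly. The comparison with the dichloro member points the same way, with a 3.1-fold higher number from compound 1 to compound 4 (0.49 log units; beyond the scatter), so the flat picture left by compounds 1 and 3, whose values lie within the scatter of each other, does not hold for every group here. The step from compound 2 to compound 4 cannot be read, since compound 2 is recorded only as a limit: the limit of < 100000 nM in this assay, at which 1 of the 4 values shown sits.

An amine or a hydroxyl group in the same place on the benzyl ring would help show whether this rise belongs to methoxy alone or extends to other groups that are not halogens. From the compounds shown here alone, whether the second methoxy of compound 2 moves the number further also stays open, as the value of that compound is a limit and not a number.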